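Replacing the aryl group of compound 3

The source may hold more compounds than are shown below. What is called first, only, known or untested is meant among the compounds shown, and "the series" means these compounds.

compound 1 `O=C(CN1CCN(c2nnc(Cc3ccncc3)c3ccccc23)CC1)Nc1cccc(Br)c1` gives 1530 nM
compound 2 `O=C(CN1CCN(c2nnc(Cc3ccncc3)c3ccccc23)CC1)Nc1ccc(Br)cc1` gives 2710 nM
compound 3 `O=C(CN1CCN(c2nnc(Cc3ccncc3)c3ccccc23)CC1)Nc1ccc(F)c(C(F)(F)F)c1` gives 16000 nM

In a functional assay on A549 cells (Homo sapiens) for cytotoxicity, read by MTT assay, with a stated time of 72 h (a higher number here means a weaker inhibitor, a lower number a stronger inhibitor), compound 3 has the highest number of the three and is the weakest. Compound 4 `Cc1ccc(F)cc1NC(=O)CN1CCN(c2nnc(Cc3ccncc3)c3ccccc23)CC1` carries 5-fluoro-2-methylphenyl in place of 4-fluoro-3-(trifluoromethyl)phenyl on an amide-type nitrogen, a change counted as 5-fluoro-2-methylphenyl in place of 4-fluoro-3-(trifluoromethyl)phenyl on an amide-type nitrogen with the shared core untouched. Among the measured compounds shown here, three measured steps concern this nitrogen. The large 10-fold higher number from compound 1 to compound 3 (1.02 log units; beyond the scatter) and the modest 5.9-fold higher number from compound 2 to compound 3 (0.77 log units; beyond the scatter) both rise to compound 3, while a 1.8-fold higher number from compound 1 to compound 2 (0.25 log units; within the scatter) stays within the scatter. For the measured compounds named here, no measured compound carries the entering group, so the guide is loose. A move back toward the two bromophenyl compounds is expected, an estimated 3.2-fold lower number from compound 3 to compound 4 (0.51 log units; beyond the scatter) in this assay on this reading. For compound 4 the estimate is 5000 nM with an expected range of 1500 nM to 16000 nM before any measurement.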

Compound 4, half-maximal inhibitory concentration: 38900 nM
Beside the measured number, compound 4's estimate is 7.8-fold (0.89 log units) below it; the measured number lies above the stated range.
By their numbers in this assay, from the lowest: compounds 1 and 2 (each within the scatter of the next); then compound 3; then compound 4.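

In this assay the change to 5-fluoro-2-methylphenyl on the amide-type nitrogen pushes the number further up, with a 2.4-fold higher number from compound 3 to compound 4 (0.39 log units; beyond the scatter), so it brings no return toward the bromophenyl compounds. Against those two the gap widens, with a 14-fold higher number from compound 2 to compound 4 (1.16 log units; beyond the scatter) and a 25-fold higher number from compound 1 to compound 4 (1.41 log units; beyond the scatter), which leaves compound 4 the weakest of the four and both fluorine-bearing aryl groups above both bromophenyl groups.

The compounds shown leave open whether a plain phenyl or a chlorophenyl on this nitrogen would sit with the bromophenyl compounds or with the fluorine-bearing ones. Nothing available gives a reason for these differences.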